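Cytotoxicity limits in a biaryl amide series

The source may report more compounds than this note shows. Statements on the series, on what has been measured and on what is new or still open speak of the compounds shown alone.

Measured compounds:
- compound 1 `CC(C)N(Cc1cccc(OCCCCCC(=O)O)c1)C(=O)c1ccc(-c2cccc(N(C)C)c2)cc1`: in an ADME assay on Raji cells (Homo sapiens) for cytotoxicity, read by CellTiter-Glo and resazurin assay, with a stated time of 72 h (on this read-out lower numbers stand for an effect already at smaller amounts and higher numbers for an effect only at larger amounts of compound), compound 1 gives > 26000 nM, a limit of the assay.
- compound 2 `CC(C)COc1cccc(-c2ccc(C(=O)N(Cc3cccc(OCCCCCC(=O)O)c3)C(C)C)cc2)c1`: in this assay compound 2 gives > 26000 nM, a limit.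
- compound 3 `CCOC(=O)CCCCCOc1cccc(CN(C(=O)c2ccc(-c3cccc(N(C)C)c3)cc2)C(C)C)c1`: in this assay compound 3 gives > 26000 nM, a limit.

Compound 3 therefore stands only at the limit of > 26000 nM in this assay, at which 3 of the 3 values shown sit, with no number of its own. Compound 4 `CCOC(=O)CCCCCOc1cccc(CN(C(=O)c2ccc(-c3cccc(OC(C)C)c3)cc2)C(C)C)c1` differs from compound 3 by isopropoxy in place of dimethylamino on an aromatic carbon. The step that the two limits leave unreadable from compound 1 to compound 2 covers the same exchange of a dimethylamino for an alkoxy group, and a step that the two limits leave unreadable from compound 1 to compound 3 the ester shared by compound 3 and compound 4; both are unreadable from the limits, so no direction can be set. Compound 4 is expected to stay at the limit, an estimated step that the limit leaves unreadable from compound 3 to compound 4. The estimate for compound 4 in this assay is 40000 nM, within 20000 nM to 120000 nM.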

Compound 4, half-maximal effective concentration: > 26000 nM
Compound 4 ended at the assay's limit; the forecaster's own chance of this, stated with the estimate: 85%; the middle value does not contradict the limit.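

No new step can be read between compound 3 and compound 4 in this assay, since both stand only at a limit: the limit of > 26000 nM in this assay, at which 4 of the 4 values shown sit. The compounds shown leave open in this assay at what concentration any of them would give an effect, and whether isopropoxy in place of dimethylamino alters it.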